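Fluoro-substituted benzylaminopurine ribosides: cytotoxicity notes

This account rests on a few compounds, and the source may have more. Where it says the series, first, only, none or still open, it means among the compounds named here.

Measured so far:
- compound 1 `OC[C@H]1O[C@@H](n2cnc3c(NCc4ccccc4F)ncnc32)[C@H](O)[C@@H]1O`: > 166000 nM
- compound 2 `COc1ccccc1CNc1ncnc2c1ncn2[C@@H]1O[C@H](CO)[C@@H](O)[C@H]1O`: 140000 nM

Compound 1 `OC[C@H]1O[C@@H](n2cnc3c(NCc4ccccc4F)ncnc32)[C@H](O)[C@@H]1O` is reported in an ADME assay on NIH3T3 cells (Mus musculus) for cytotoxicity, with a stated time of 72 h (on this read-out higher numbers stand for weaker inhibition and lower numbers for stronger inhibition), only as a limit, > 166000 nM, so no number is available for it. Compound 2 `COc1ccccc1CNc1ncnc2c1ncn2[C@@H]1O[C@H](CO)[C@@H](O)[C@H]1O` gives 140000 nM in this assay. For the measured compounds named here, the single measured step, an at least 1.1-fold lower number from compound 1 to compound 2 (0.07 log units; that floor lies within the scatter), is a change of methoxy in place of fluoro on an aromatic carbon, and its floor lies within the scatter; both compounds therefore sit in the same weak region, one of them at the limit, as the limit of > 166000 nM in this assay, at which 1 of the 2 values shown sits, records.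

Compound 3 `OC[C@H]1O[C@@H](n2cnc3c(NCc4ccc(F)cc4F)ncnc32)[C@H](O)[C@@H]1O` differs from compound 1 by fluoro in place of hydrogen on an aromatic carbon. Going by the values given here, no measured step covers fluoro in place of hydrogen, so the only guide is that neither compound measured here leaves the weak region, and the one measured step shows no movement beyond the scatter. The expectation for compound 3 in this assay is therefore a step of a number no higher from compound 1 to compound 3 (the limit leaves the size open), that is, no change beyond the scatter from compound 1, and most likely another limit. Compound 3 is estimated at 166000 nM, in the range 80000 nM to 400000 nM.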

Compound 3, half-maximal inhibitory concentration: > 166000 nM
Compound 3 ended at the assay's limit; the forecaster's own chance of this, stated with the estimate: 70%; the middle value sits exactly at the limit.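

In this assay compound 3 gives > 166000 nM, which is a limit of the assay and not a number. Fluoro in place of hydrogen on the aromatic carbon para to a large group and meta to a fluoro group therefore leaves the series at the ceiling of the read-out, and the steps between the two limit compounds cannot be read: the limit of > 166000 nM in this assay, at which 2 of the 3 values shown sit. The only readable step is an at least 1.1-fold higher number from compound 2 to compound 3 (0.07 log units; that floor lies within the scatter), a change to 2,4-difluorophenyl in place of 2-methoxyphenyl, so the second fluoro brings no inhibition that can be told apart from that of the methoxy compound.

As far as these compounds go, the size of any effect of fluoro in place of hydrogen stays unknown, as does how far the true values of the two limit compounds lie from the ceiling. Also open, from the compounds shown here alone, is whether a different group at this place on the ring, such as an amine or a carboxylic acid, would give a number clear of the limit and show any real movement in this weak region.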